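The compounds below may be only part of what the source reports. "The series", "measured", "known", "first", "only" and "open" are said of these compounds alone.

Measured compounds in a functional assay for agonist activity at G protein-coupled receptor 88 (Homo sapiens), read by HTRF and cAMP accumulation; a higher number here means that more compound is needed for the effect, a lower number that less compound is needed:
compound 1 `CC(C)C[C@@H](N)CN(C(=O)[C@@H]1C[C@H]1c1ccccc1)c1ccc(-c2ccccc2)cc1` gives 1.8 nM
compound 2 `CC[C@H](C)[C@@H](CN(C(=O)[C@@H]1C[C@H]1c1ccccc1)c1ccc(-c2ccccc2)cc1)NC(C)=O` gives 5.8 nM
compound 3 `N[C@@H](CC1CCCCC1)CN(C(=O)[C@@H]1C[C@H]1c1ccccc1)c1ccc(-c2ccccc2)cc1` gives 1.7 nM

Compound 1 stands second highest of the three numbers in this assay, with compound 3 nearest (a 1.1-fold lower number from compound 1 to compound 3 (0.02 log units; within the scatter)) and compound 2 furthest (a 3.2-fold higher number from compound 1 to compound 2 (0.51 log units; beyond the scatter)). The step of a 3.4-fold lower number from compound 2 to compound 3 (0.53 log units; beyond the scatter) fits the same picture: exchanging one amino-bearing side chain for another leaves the number where it was, whereas the acetamido variant sits a modest step higher.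

Compound 4 `O=C([C@@H]1C[C@H]1c1ccccc1)N(CC1CCCNC1)c1ccc(-c2ccccc2)cc1` differs from compound 1 as follows: piperidin-3-yl in place of 1-amino-3-methylbutyl on a saturated chain carbon bound to an amide-type nitrogen. Going by the values given here, no measured step covers this change directly. The step from compound 1 to compound 3 shows that reshaping the carbon part of the side chain while keeping a free amine stays within the scatter; the step from compound 1 to compound 2, where the amine becomes an acetamide, is beyond it. Here the amine is kept but moved into a piperidin-3-yl ring, so a modest loss is expected, a 3.3-fold higher number from compound 1 to compound 4 (0.52 log units; beyond the scatter). Compound 4 is therefore estimated at 6 nM, with a range of 1.5 nM to 25 nM.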

Compound 4, half-maximal effective concentration: 10 nM
Beside the measured number, compound 4's estimate is 1.7-fold (0.22 log units) below it, and the stated range covers the measured number.
By their numbers in this assay, from the lowest: compounds 3 and 1 (each within the scatter of the next); then compounds 2 and 4 (each within the scatter of the next).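

In this assay, going by these compounds alone, piperidin-3-yl is the first group at this place that keeps an amine and still moves the number beyond the scatter: a 5.6-fold higher number from compound 1 to compound 4 (0.74 log units; beyond the scatter) and a 5.9-fold higher number from compound 3 to compound 4 (0.77 log units; beyond the scatter). An amine on the saturated chain carbon bound to an amide-type nitrogen is thus not enough on its own to hold the low numbers, and the piperidin-3-yl and acetamido side chains cannot be told apart, with a 1.7-fold higher number from compound 2 to compound 4 (0.24 log units; within the scatter). No evidence in hand bears on this result.

The compounds shown leave open whether the ring itself or the amine nitrogen held within it accounts for the step, a question that a piperidin-4-yl, a pyrrolidin-3-yl or an open 2-(methylamino)-4-methylpentyl group could address. They also leave open how the separate stereoisomers of the piperidin-3-yl compound would compare.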